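The source may report more compounds than this note shows. Statements on the series, on what has been measured and on what is new or still open speak of the compounds shown alone.

Compound 1 `Nc1nc2cc(-c3nn(CCCCCCCCCC(=O)NO)c4ncnc(N)c34)ccc2o1`: > 50000 nM
Compound 2 `Nc1nc2cc(-c3nn(CCC(=O)NO)c4ncnc(N)c34)ccc2o1`: > 150000 nM

In a functional assay on HeLa cells (Homo sapiens) for inhibition, read by MTT assay, with a stated time of 72 h (a higher number here means a weaker inhibitor, a lower number a stronger inhibitor), compound 2 gives > 150000 nM, which is a limit and not a number. Compound 1 gives > 50000 nM, and this too is a limit. Neither compound therefore has an exact potency to build on.

Compound 3 `Nc1nc2cc(-c3nn(CCCCCC(=O)NO)c4ncnc(N)c34)ccc2o1` changes the chain of compound 2: 3-(hydroxycarbamoyl)propyl in place of hydroxycarbamoyl on a saturated chain carbon, two bonds along the chain from an aromatic nitrogen. In words, 3-(hydroxycarbamoyl)propyl stands in place of hydroxycarbamoyl on a saturated chain carbon, two bonds along the chain from an aromatic nitrogen. Its chain length falls between those of the two measured compounds.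

For the measured compounds named here, the only measured step that bears on this change is a step that the two limits leave unreadable from compound 1 to compound 2, so it offers neither a size nor a direction. A cautious expectation is an at least 3.0-fold lower number from compound 2 to compound 3 (0.47 log units; beyond the scatter), and compound 3 may well return only a limit too. For compound 3 the estimated value in this assay is 50000 nM, with an expected range of 8000 nM to 200000 nM.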

Compound 3, half-maximal inhibitory concentration: 15400 nM
Beside the measured number, compound 3's estimate is 3.2-fold (0.51 log units) above it, within the range that was stated.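

Compound 3 gives the first exact number at this position in this assay, and it shows that chain length matters here: 3-(hydroxycarbamoyl)propyl in place of hydroxycarbamoyl brings an at least 9.7-fold lower number from compound 2 to compound 3 (0.98 log units; beyond the scatter), while shortening the longest chain shown brings an at least 3.2-fold lower number from compound 1 to compound 3 (0.51 log units; beyond the scatter). The first of these sizes is only a minimum because compound 2 stands at a limit: the limit of > 150000 nM in this assay, at which 1 of the 3 values shown sits. The second is also only a minimum because compound 1 stands at a limit: the limit of > 50000 nM in this assay, at which 1 of the 3 values shown sits.

The step between the two limits cannot be read, and three chain lengths do not settle which length does best, nor how far the number could fall with a chain slightly shorter or longer than that of compound 3. Also open, on these data alone, is how a carboxylic acid in place of the hydroxycarbamoyl end would read.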